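Toward compound 3: half-life after a ring swap

The source may report more compounds than this note shows. Statements on the series, on what has been measured and on what is new or still open speak of the compounds shown alone.

Compound 1, `CCc1nc2cc(Cl)ccn2c1C(=O)NCc1ccc2oc(C3CCCCC3)nc2c1`: 0.158 h
Compound 2, `CCc1nc2ccc(Cl)cn2c1C(=O)NCc1ccc2[nH]ccc2c1`: 0.113 h

In an ADME assay on microsomes from liver (Rattus norvegicus) for metabolic stability (a higher number here means that the compound lasts longer, a lower number that the compound disappears faster), compound 1 gives 0.158 h, the higher of the two numbers, while compound 2 gives 0.113 h, and the two values lie within the scatter of each other. Compound 3 is `CCc1nc2cc(Cl)ccn2c1C(=O)NCc1ccc2oc(-c3ccc(OC(F)(F)F)cc3)nc2c1`, which differs from compound 1 in one place: 4-(trifluoromethoxy)phenyl in place of cyclohexyl on an aromatic carbon. For the measured compounds named here, no measured pair shows a step of this kind, so the expectation rests only on the value of compound 1 in this assay, 0.158 h. A modest rise is expected, the step from a 1.6-fold higher number from compound 1 to compound 3 (0.20 log units; within the scatter) being small. For compound 3 the estimate in this assay is 0.25 h, within 0.1 h to 0.6 h.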

Compound 3, half-life: > 2 h
Compound 3: a limit, no number; the forecaster's own chance of this, stated with the estimate: 5%; middle value at least 8.0-fold (0.90 log units) away from the limit.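

The earlier compounds shown here offered no step at this place, the aromatic carbon next to the ring nitrogen and the ring oxygen. Here, 4-(trifluoromethoxy)phenyl in place of cyclohexyl gives an at least 12-fold higher number from compound 1 to compound 3 (1.10 log units; beyond the scatter), so the group at this place can change the half-life in this assay well beyond the scatter. For compound 3, > 2 h is a limit of the assay and not a number, so the true size of the step stays unknown: the limit of > 2 h in this assay, at which 1 of the 3 values shown sits.

The compounds shown leave open whether the phenyl ring alone or its trifluoromethoxy group accounts for the step. From the compounds shown here alone, how an unsubstituted phenyl or a piperidine at this place would compare also remains open.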